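A few compounds are considered here, and "the series" means these few. Any claim that something is new, unique, unknown or untested is made for them only; others in the source may bear on it.

Compound 1 `COc1ccc(C2CC(=NOC(=O)c3ccc(Br)cc3)CC(c3ccc(OC)cc3)N2C)cc1` and compound 2 `COc1ccc(C2CC(=NOC(=O)c3cccc(Cl)c3)CC(c3ccc(OC)cc3)N2C)cc1` share one core and differ only in the aryl group on the carbonyl carbon. In a functional assay, with a stated time of 30 min (a higher number here means a weaker inhibitor, a lower number a stronger inhibitor), compound 1 gives 121000 nM, and compound 2 gives 136000 nM; the step of a 1.1-fold higher number from compound 1 to compound 2 (0.05 log units; within the scatter) is within the scatter. Compound 2 thus stands with the highest of the two numbers, though not separable from compound 1. Compound 3 `COc1ccc(C2CC(=NOC(=O)c3cc([N+](=O)[O-])cc([N+](=O)[O-])c3)CC(c3ccc(OC)cc3)N2C)cc1` carries 3,5-dinitrophenyl in place of 3-chlorophenyl on a carbonyl carbon. Among the compounds with values here, only the step from compound 1 to compound 2 bears on an aryl swap at this carbonyl, and it was within the scatter, so no step beyond the scatter is expected in this assay, giving a 1.0-fold lower number from compound 2 to compound 3 (0.02 log units; within the scatter). Compound 3 is estimated at 130000 nM, with a range from 50000 nM to 350000 nM.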

Compound 3, half-maximal inhibitory concentration: 312000 nM
For compound 3 the middle estimate is 2.4-fold (0.38 log units) below the measured one; the range from low to high includes it.
By their numbers in this assay, from the lowest: compounds 1 and 2 (each within the scatter of the next); then compound 3.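

In this assay the aryl group on this carbonyl carbon is not indifferent: 3,5-dinitrophenyl gives a 2.3-fold higher number from compound 2 to compound 3 (0.36 log units; beyond the scatter) and a 2.6-fold higher number from compound 1 to compound 3 (0.41 log units; beyond the scatter), modest steps but beyond the scatter, which the swap between 4-bromophenyl and 3-chlorophenyl did not reach. Within the data shown here, the one change that clears the scatter here runs towards weaker inhibition. Nothing available accounts for this shift.

Going by these compounds, whether any group at this carbonyl carbon gives a lower number than compound 1 and compound 2 stays open. So does the outcome with an aminophenyl or carboxyphenyl group, or a longer alkyl chain in place of the aryl ring.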